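Piperazine cap series: removing the methylsulfonyl group

The compounds below may be only part of what the source reports. "The series", "measured", "known", "first", "only" and "open" are said of these compounds alone.

Compound 1 `O=C(NCC1CCN(CCCS(=O)(=O)N2CCN(Cc3cccnc3)CC2)CC1)c1cccc2c1OCCO2` carries a (pyridin-3-yl)methyl group on the piperazine nitrogen and gives 0.159 nM in an assay on isolated protein for inhibition of 5-hydroxytryptamine receptor 4 (Homo sapiens); a lower number here means a stronger inhibitor, a higher number a weaker inhibitor. Compound 2 `CS(=O)(=O)N1CCN(S(=O)(=O)CCCN2CCC(CNC(=O)c3cccc4c3OCCO4)CC2)CC1` carries a methylsulfonyl group in its place and gives 0.316 nM in this assay. Among the compounds with values here, the single measured step, a 2.0-fold higher number from compound 1 to compound 2 (0.30 log units; within the scatter), leaves the two values indistinguishable. Compound 2 therefore shows the highest of the two numbers, with compound 1 nearest to it, and the gap between them is inside the scatter.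

Compound 3 `O=C(NCC1CCN(CCCS(=O)(=O)N2CCNCC2)CC1)c1cccc2c1OCCO2` is unmeasured; the change from compound 2 is hydrogen in place of methylsulfonyl on an amine nitrogen in a ring. Within the data shown here, only the step from compound 1 to compound 2 bears on this position, and it was within the scatter; no measured step removes the cap entirely, so the outcome is open. Compound 3 is expected to stay close to compound 2, with a step of a 1.3-fold higher number from compound 2 to compound 3 (0.10 log units; within the scatter) in this assay. The estimate for compound 3 is 0.4 nM, with a range of 0.1 nM to 1.6 nM.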

Compound 3, inhibition constant: 0.159 nM
The estimate for compound 3 lay 2.5-fold (0.40 log units) above the measured number; the measured number falls inside the stated range.
By their numbers in this assay, from the lowest: compounds 1, 3 and 2 (each within the scatter of the next).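

Taking the cap off the amine nitrogen in the ring altogether gives a 2.0-fold lower number from compound 2 to compound 3 (0.30 log units; within the scatter) in this assay and, against the other cap, no change at the digits printed from compound 1 to compound 3 (within the scatter) in the same assay. The earlier pair compared only two caps, whereas the three compounds now cover methylsulfonyl, (pyridin-3-yl)methyl and plain hydrogen at this position with every step within the scatter, so neither cap is needed on this nitrogen to retain the values seen here. No supporting data bear on why this position reads so flat.

Left open is whether the same holds for other groups on this nitrogen, such as an acetyl group or a carboxylic acid on a short chain. Also open, going by these compounds, is whether the piperazine ring itself can give way to an open-chain amine.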